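The source may report more compounds than this note shows. Statements on the series, on what has been measured and on what is new or still open speak of the compounds shown alone.

Measured so far:
compound 1, `O=C(CCCCCCc1ccccc1)c1ncc(-c2cncnc2)o1`, 22 nM
compound 2, `O=C(CCCCCCc1ccccc1)c1ncc(-c2nnn[nH]2)o1`, 63 nM

In an assay (Rattus norvegicus) for inhibition of Fatty-acid amide hydrolase 1 (Homo sapiens) (on this read-out lower numbers stand for stronger inhibition and higher numbers for weaker inhibition), compound 2 gives the higher of the two numbers, and the step of a 2.9-fold higher number from compound 1 to compound 2 (0.46 log units; beyond the scatter) shows how far it sits from compound 1. Compound 3, `O=C(CCCCCCc1ccccc1)c1ncc(F)o1`, differs from compound 2 by fluoro in place of 1H-tetrazol-5-yl on an aromatic carbon. Among the measured compounds shown here, no measured step swaps an aromatic ring for a single atom here; the only measured step exchanges one ring for another and is modest, so it bears on this change only loosely. Removing the whole ring is expected to weaken binding more clearly, giving a 9.5-fold higher number from compound 2 to compound 3 (0.98 log units; beyond the scatter). Compound 3 is therefore estimated at 600 nM, within 150 nM to 2500 nM.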

Compound 3, inhibition constant: 30 nM
Compound 3: middle estimate off by 20-fold (1.30 log units), on the high side; measured number below the stated range.
By their numbers in this assay, from the lowest: compounds 1 and 3 (each within the scatter of the next); then compound 2.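

In this assay, this position on the shared core does not depend on keeping an aromatic ring: the single fluoro atom gives a 2.1-fold lower number from compound 2 to compound 3 (0.32 log units; beyond the scatter), and the comparison with the pyrimidin-5-yl compound gives a 1.4-fold higher number from compound 1 to compound 3 (0.13 log units; within the scatter). So a ring with a hydrogen-bond donor and a ring without one are both matched or bettered here by a group with no ring at all. Nothing at hand explains this result.

The compounds shown leave open how a plain hydrogen, an amine or a carboxylic acid at this position would compare.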